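The source may hold more compounds than are shown below. What is called first, only, known or untested is meant among the compounds shown, and "the series" means these compounds.

Measured so far:
Compound 1 `C=CCc1cc(-c2cccc(C(F)(F)F)c2)ccc1O`: 76000 nM
Compound 2 `C=CCc1cc(-c2ccccc2)ccc1O`: > 100000 nM (a limit)
Compound 3 `C=CCc1cc(-c2ccc(F)cc2)ccc1O`: > 100000 nM (a limit)

In a functional assay on HUVEC cells (Homo sapiens) for antiproliferative activity, read by MTT assay, with a stated time of 24 h (a lower number here means a stronger inhibitor, a higher number a weaker inhibitor), compound 2 stands at > 100000 nM, which is a limit of the assay and not a number. That is the limit of > 100000 nM in this assay, at which 2 of the 3 values shown sit. Compound 4 `C=CCc1cc(-c2ccccc2C(F)(F)F)ccc1O` carries trifluoromethyl in place of hydrogen on an aromatic carbon, ortho to a large group: trifluoromethyl in place of hydrogen on an aromatic carbon. The nearest measured step is the same exchange in reverse, with the group placed differently: an at least 1.3-fold higher number from compound 1 to compound 2 (0.11 log units; that floor lies within the scatter). The fluoro step tells nothing about size: a step that the two limits leave unreadable from compound 2 to compound 3. In this assay only a small shift toward a lower number is therefore expected, and none beyond the scatter can be claimed. The expected change is an at least 1.1-fold lower number from compound 2 to compound 4 (0.04 log units; that floor lies within the scatter). For compound 4 the estimate is 90000 nM, with an expected range from 50000 nM to 160000 nM.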

Compound 4, half-maximal inhibitory concentration: 82000 nM
For compound 4 the middle estimate is 1.1-fold (0.04 log units) above the measured one, within the range that was stated.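

Placed ortho to a large group, trifluoromethyl gives a result in this assay that can be read only as a floor (an at least 1.2-fold lower number from compound 2 to compound 4 (0.08 log units; that floor lies within the scatter)). Compound 1 (76000 nM) and compound 4 (82000 nM), which carry the group placed differently, lie within the scatter of each other, so placement shows no readable effect here. Compound 2 carries a limit, not a number, and the step rests on it: the limit of > 100000 nM in this assay, at which 2 of the 4 values shown sit.

From the compounds shown here alone, whether an amine or a carboxylic acid at this position would give a lower number remains open.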